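The source may report more compounds than this note shows. Statements on the series, on what has been measured and on what is new or still open speak of the compounds shown alone.

The measured compounds:
compound 1 `O=C(Nc1ccc(Oc2ccncc2-c2cccnc2)c(F)c1)c1ccnn(-c2ccc(Cl)cc2)c1=O`, which in a functional assay on MDA-MB-231 cells (Homo sapiens) for cytotoxicity, read by MTT assay, with a stated time of 72 h (a lower number here means a stronger inhibitor, a higher number a weaker inhibitor), gives 4840 nM;
compound 2 `Cn1cc(-c2ccccc2)cc(C(=O)Nc2ccc(Oc3ccncc3-c3cccnc3)c(F)c2)c1=O`, which in this assay gives 9500 nM.

Compound 2 stands at one end of this pair, and its distance from compound 1 lies within the scatter, so the two cannot be told apart. Compound 3 `Cn1cc(-c2ccc(F)cc2)cc(C(=O)Nc2ccc(Oc3ccncc3-c3cccnc3)c(F)c2)c1=O` differs from compound 2 by fluoro in place of hydrogen on an aromatic carbon. Among the compounds with values here, no measured pair shows this change, so the step of a 1.2-fold lower number from compound 2 to compound 3 (0.07 log units; within the scatter) is expected to be none beyond the scatter. Compound 3 is therefore estimated at 8000 nM, with a range from 3000 nM to 25000 nM.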

Compound 3, half-maximal inhibitory concentration: 11900 nM
The estimate for compound 3 lay 1.5-fold (0.17 log units) below the measured number; the range from low to high includes it.
By their numbers in this assay, from the lowest: compounds 1, 2 and 3 (each within the scatter of the next, the first and the last beyond it).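

In this assay, within the data shown here, the change from phenyl to 4-fluorophenyl gives a 1.3-fold higher number from compound 2 to compound 3 (0.10 log units; within the scatter) and so offers the first single-place comparison: at this position, para to a large group, fluoro in place of hydrogen produces no change that can be read. Nothing measured here bears on why this is so. From the compounds shown here alone, whether a different group at the same place, such as an amine, a carboxylic acid or a longer chain, would move the number beyond the scatter remains open.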